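A few compounds are considered here, and "the series" means these few. Any claim that something is new, unique, unknown or untested is made for them only; others in the source may bear on it.

Working notes on the series. Three compounds share one core and differ only in the group on a nitrogen on an aromatic ring. Compound 1 `CC1CCC(Nc2nc(C(F)(F)F)ccc2CNC(=O)C(C)c2ccc(NS(C)(=O)=O)c(F)c2)CC1` gives 1130 nM in a functional assay on CHO-K1 cells for antagonist activity at transient receptor potential cation channel subfamily V member 1 (Homo sapiens), read by FLIPR; on this read-out lower numbers stand for stronger inhibition and higher numbers for weaker inhibition. Compound 2 `CC(C(=O)NCc1ccc(C(F)(F)F)nc1Nc1ccccc1)c1ccc(NS(C)(=O)=O)c(F)c1` gives 1400 nM in this assay; the step of a 1.2-fold higher number from compound 1 to compound 2 (0.09 log units; within the scatter). Compound 3 `CC(C(=O)NCc1ccc(C(F)(F)F)nc1NCc1ccc(Cl)cc1)c1ccc(NS(C)(=O)=O)c(F)c1` gives 414 nM in this assay, the lowest of the three numbers; the steps of a 2.7-fold lower number from compound 1 to compound 3 (0.44 log units; beyond the scatter) and a 3.4-fold lower number from compound 2 to compound 3 (0.53 log units; beyond the scatter).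

Compound 4 `CC(C(=O)NCc1ccc(C(F)(F)F)nc1N(C)C)c1ccc(NS(C)(=O)=O)c(F)c1` is not yet measured in this assay. Change from compound 3: dimethylamino in place of (4-chlorobenzyl)amino on an aromatic carbon. The two steps that bear on it are those into compound 3, in which the 4-chlorobenzyl group gave lower numbers than either the 4-methylcyclohexyl or the phenyl group, both beyond the scatter but modest. Compound 4 keeps neither the ring nor the donor of that group, so the expectation is a step in the other direction, beyond the scatter, of roughly the size seen in those two steps or somewhat larger: a 7.2-fold higher number from compound 3 to compound 4 (0.86 log units; beyond the scatter). Compound 4 is therefore expected to give about 3000 nM in this assay, with a plausible range from 800 nM to 12000 nM.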

Compound 4, half-maximal inhibitory concentration: 2390 nM
For compound 4 the middle estimate is 1.3-fold (0.10 log units) above the measured one; the range from low to high includes it.
By their numbers in this assay, from the lowest: compound 3; then compounds 1, 2 and 4 (each within the scatter of the next, the first and the last beyond it).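

At this position, dimethylamino in place of (4-chlorobenzyl)amino removes the ring and the hydrogen-bond donor together and gives a 5.8-fold higher number from compound 3 to compound 4 (0.76 log units; beyond the scatter). The same exchange gives a 1.7-fold higher number from compound 2 to compound 4 (0.23 log units; within the scatter) against anilino, and a 2.1-fold higher number from compound 1 to compound 4 (0.33 log units; beyond the scatter) against (4-methylcyclohexyl)amino. A ring and a donor on this carbon's amino group are therefore not enough in themselves: compound 2 has both yet cannot be told from compound 4, while compounds 1 and 3 both stand apart from compound 4 with the same two features.

Nothing available explains any of these steps. Also open, going by these compounds, is whether the chlorine or the carbon link of the 4-chlorobenzyl group carries its advantage, which unsubstituted benzylamino and 2-phenylethylamino at this position would help to separate.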